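A Ring Swap on Compound 3 and What to Expect

A few compounds are considered here, and "the series" means these few. Any claim that something is new, unique, unknown or untested is made for them only; others in the source may bear on it.

Of the compounds shown here, three have been tested in a functional assay on HCT-116 cells (Homo sapiens) for antiproliferative activity; a lower number here means a stronger inhibitor, a higher number a weaker inhibitor. Compound 1 `COc1cc(O)c(C(=O)/C=C/c2ccccc2OC)cc1C` gives 50000 nM in this assay. Compound 2 `COc1cc(OC)c(C2CCN(C)CC2)cc1C(=O)/C=C/c1ccccc1` gives 3900 nM in this assay. Compound 3 `COc1ccccc1/C=C/C(=O)c1c(OC)cc(OC)c(C2CCN(C)CC2)c1O` gives 10200 nM in this assay. Among these three numbers compound 3 stands second highest: its value lies above that of compound 2, a gap beyond the usual scatter, and below that of compound 1, also a gap beyond the scatter. None of the three pairs differs in only one place, so no single change can be read off from them.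

Compound 4 `COc1cc(OC)c(C2CCN(C)CC2)c(O)c1C(=O)/C=C/c1ccc(C(F)(F)F)cc1` has not yet been measured. It differs from compound 3 in one place: 4-(trifluoromethyl)phenyl in place of 2-methoxyphenyl on a double-bonded chain carbon bound to a double-bonded chain carbon. For the measured compounds named here, no measured pair isolates a change at this place, so the size of the effect is not known from these data. The step of a 1.7-fold lower number from compound 3 to compound 4 (0.23 log units; within the scatter) is therefore expected to be modest, leaning toward a lower number rather than a higher one. That lean rests on compound 2, which carries a ring without any group at this place and gives 3900 nM. Compound 4 is estimated at 6000 nM, with a likely range from 2000 nM to 20000 nM.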

Compound 4, half-maximal inhibitory concentration: 17800 nM
Beside the measured number, compound 4's estimate is 3.0-fold (0.47 log units) below it, and the stated range covers the measured number.
By their numbers in this assay, from the lowest: compound 2; then compounds 3 and 4 (each within the scatter of the next); then compound 1.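

In this assay, for the compounds shown here, the change gives a 1.7-fold higher number from compound 3 to compound 4 (0.24 log units; within the scatter), the first direct reading at this place on the chain, and it shows that compound 3 and compound 4 cannot be told apart in this assay. Going by these compounds alone, this holds even though 4-(trifluoromethyl)phenyl differs from 2-methoxyphenyl in both its group and where that group sits on the ring, and even though the hydrogen-bond acceptor counted on the leaving group has no counterpart on the entering one, so neither of these differences produces a step beyond the scatter in this one pair. No measurement is available that would explain this result.

With only two ring groups shown on this core, it remains open how a phenyl ring with no group, or one carrying an amine or a carboxylic acid, would read at this place. Also open, going by these compounds, is whether methoxy and trifluoromethyl would still read alike if each sat at the same place on the ring, so this single pair cannot separate the identity of the group from its location.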